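Replacing the phenyl of compound 3 with acetyl

The source may report more compounds than this note shows. Statements on the series, on what has been measured and on what is new or still open speak of the compounds shown alone.

In an ADME assay on Vero 76 cells (Chlorocebus sabaeus) for cytotoxicity, read by crystal violet staining, with a stated time of 96 h (a lower number here means that less compound is tolerated, a higher number that more compound is tolerated), compound 1 (`FC(F)(F)c1cccc(NC(=S)Nc2ccc(I)cc2)c1`) gives 9500 nM and compound 2 (`N#Cc1ccc(NC(=S)Nc2cccc(C(F)(F)F)c2)cc1`) gives 10000 nM. These two values lie within the scatter of each other, as a 1.1-fold higher number from compound 1 to compound 2 (0.02 log units; within the scatter) shows. Compound 3 (`FC(F)(F)c1cccc(NC(=S)Nc2ccccc2)c1`), which has hydrogen on the aromatic carbon where the other two have iodo and cyano, gives 39000 nM. That is the highest of the three numbers, and its gaps to both neighbours lie beyond the scatter.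

Compound 4 (`CC(=O)NC(=S)Nc1cccc(C(F)(F)F)c1`) has acetyl in place of phenyl on an amide-type nitrogen, and the change is acetyl in place of phenyl on an amide-type nitrogen. Among the compounds with values here, no measured step makes this exchange, so the evidence is indirect. The closest guides are a 4.1-fold higher number from compound 1 to compound 3 (0.61 log units; beyond the scatter) and a 3.9-fold higher number from compound 2 to compound 3 (0.59 log units; beyond the scatter), both modest, and in each a group leaves the same phenyl that is lost in compound 4. On the strength of those two steps, a modest further rise in this assay is expected, though the data cannot say how far they carry over to the loss of a whole ring. The expected change is a 1.7-fold higher number from compound 3 to compound 4 (0.22 log units; within the scatter). Compound 4 is estimated at 65000 nM, with an expected range of 25000 nM to 120000 nM.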

Compound 4, half-maximal cytotoxic concentration: > 100000 nM
Compound 4 was reported as a limit (the forecaster's own chance of this, stated with the estimate: 35%); middle value at least 1.5-fold (0.18 log units) from the limit.
By their numbers in this assay, from the lowest: compounds 1 and 2 (each within the scatter of the next); then compound 3. At a limit, above all of these: compound 4.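

In this assay, within the data shown here, the earlier compounds changed only a substituent on the phenyl, whereas compound 4 shows that the phenyl on the amide-type nitrogen can itself give way to acetyl, a group with no ring, and that the number rises further: an at least 2.5-fold higher number from compound 3 to compound 4 (0.40 log units; beyond the scatter). Among these compounds, measured against the 4-iodophenyl group instead, the same position yields an at least 10-fold higher number from compound 1 to compound 4 (1.02 log units; beyond the scatter), the only step in the set that is printed as large, and it exceeds every step among compound 1, compound 2 and compound 3. The value of compound 4 is a limit and not a number, so both of these steps give only a lower bound on the change: the limit of > 100000 nM in this assay, at which 1 of the 4 values shown sits.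

The compounds shown do not separate the loss of the ring from the arrival of the acetyl carbonyl, so it remains open whether a plain hydrogen, a methyl or a longer acyl chain such as butanoyl on the same nitrogen would behave like acetyl or like phenyl. They also leave open how a phenyl bearing an amine or a carboxylic acid in place of iodo or cyano would stand in this assay.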